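This account rests on a few compounds, and the source may have more. Where it says the series, first, only, none or still open, it means among the compounds named here.

Working notes on the series.

Three members of the series have numbers in an assay on Sf9 cells for inhibition of mitogen-activated protein kinase kinase kinase 14 variant S549D (Homo sapiens), with a stated time of 30 min, in the presence of a further agent that is not named here; on this read-out higher numbers stand for weaker inhibition and lower numbers for stronger inhibition. Compound 1 `CCc1ccc2ncn(-c3ccnc(N)n3)c2c1` gives 79400 nM in this assay. For the measured compounds named here, compound 2 `CC(=O)NCCCCc1ccc2ncn(-c3ccnc(N)n3)c2c1` gives 398000 nM in this assay, and the only one-place step among the measured compounds is a 5.0-fold higher number from compound 1 to compound 2 (0.70 log units; beyond the scatter). Compound 3 `C=Cc1ccnc(C#Cc2ccc3ncn(-c4ccnc(N)n4)c3c2)c1` gives 1580 nM in this assay, the lowest of the three numbers, a good distance below compound 1 and still further below compound 2.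

Compound 4 `C#Cc1ccnc(C#Cc2ccc3ncn(-c4ccnc(N)n4)c3c2)c1` is the next member and has not yet been measured. The change from compound 3 to compound 4 is ethynyl in place of vinyl on an aromatic carbon. Going by the values given here, the single measured step, from compound 1 to compound 2, concerns a saturated chain and a 2-acetamidoethyl group, so it does not bear on this exchange; nothing among the measured compounds touches a vinyl or an ethynyl group on the six-membered aromatic ring with one nitrogen. Among the compounds with values here, with the two groups of equal heavy-atom count, no donors or acceptors entering or leaving, and no comparable step in hand, the expected step is a 1.0-fold higher number from compound 3 to compound 4 (0.01 log units; within the scatter), none beyond the scatter. Compound 4 is therefore estimated at 1600 nM in this assay, with a range from 500 nM to 5000 nM.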

Compound 4, half-maximal inhibitory concentration: 316 nM
Compound 4: middle estimate off by 5.1-fold (0.70 log units), on the high side; the whole stated range lies above it.
By their numbers in this assay, from the lowest: compound 4; then compound 3; then compound 1; then compound 2.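

On an aromatic carbon of the six-membered aromatic ring with 1 nitrogen, meta to a large group and opposite the ring nitrogen, the exchange of vinyl for ethynyl gives in this assay a 5.0-fold lower number from compound 3 to compound 4 (0.70 log units; beyond the scatter) and so shows that this position is sensitive to a change that leaves the heavy-atom count and the counted hydrogen-bond donors and acceptors as they were. For the compounds shown here, the earlier step concerned only a saturated chain, whereas this one is the first read on this ring and shows that a double bond giving way to a triple bond outside the aromatic rings is enough, on its own, to move the number beyond the scatter. No measurement at hand accounts for the difference between the two groups, so the step stands as an observation only.

Going by these compounds alone, the single pair leaves open whether the lower number is particular to ethynyl or would also come with a nitrile, a propynyl group, a cyclopropyl group or an amine on the same carbon. It also leaves open how either group compares with plain hydrogen there, and whether the same exchange would give a step of similar size at another carbon of this ring.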